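A few compounds are considered here, and "the series" means these few. Any claim that something is new, unique, unknown or untested is made for them only; others in the source may bear on it.

In an assay on T-REx-293 cells for inhibition of potassium channel subfamily T member 1 (Homo sapiens), read by patch clamp (on this read-out lower numbers stand for stronger inhibition and higher numbers for weaker inhibition), the three measured compounds gave these numbers:

compound 1 `C[C@H](NC(=O)c1cc(C(F)(F)F)nn1C)c1nc(-c2cccc(F)c2)no1`: 136 nM
compound 2 `Cc1ccnc(-c2noc([C@H](C)NC(=O)c3cc(C(F)(F)F)nn3C)n2)c1`: 4470 nM
compound 3 `C[C@H](NC(=O)c1cc(C(F)(F)F)nn1C)c1nc(-c2cccnc2)no1`: 11800 nM

Compound 3 has the highest number of the three, that is, the weakest inhibition: the step of an 87-fold higher number from compound 1 to compound 3 (1.94 log units; beyond the scatter) is very large, and even against its nearest neighbour the step of a 2.6-fold higher number from compound 2 to compound 3 (0.42 log units; beyond the scatter) lies beyond the scatter.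

Compound 4 `COc1cc(-c2noc([C@H](C)NC(=O)c3cc(C(F)(F)F)nn3C)n2)ccn1` differs from compound 3 in one place: 2-methoxypyridin-4-yl in place of pyridin-3-yl on an aromatic carbon. Among the measured compounds shown here, two measured steps bear on this. The steps of an 87-fold higher number from compound 1 to compound 3 (1.94 log units; beyond the scatter) and a 33-fold higher number from compound 1 to compound 2 (1.52 log units; beyond the scatter) show that both pyridyl groups tried so far sit far above the fluorophenyl of compound 1. The step of a 2.6-fold higher number from compound 2 to compound 3 (0.42 log units; beyond the scatter) shows that a pyridyl carrying an extra group gave a modestly lower number than the plain pyridin-3-yl. Since compound 4 likewise carries a pyridyl with an extra group, a modest improvement over compound 3 in this assay is expected, roughly toward the level of compound 2: a 2.0-fold lower number from compound 3 to compound 4 (0.29 log units; within the scatter).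

The estimated value for compound 4 is 6000 nM, expected to fall between 1800 nM and 20000 nM.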

Compound 4, half-maximal inhibitory concentration: 27 nM
Estimate against measurement, compound 4: 220-fold (2.35 log units) above; the whole stated range lies above it.
By their numbers in this assay, from the lowest: compound 4; then compound 1; then compound 2; then compound 3.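

At this position on the shared core, a ring nitrogen does not by itself cost inhibition in this assay: the 2-methoxypyridin-4-yl group gives a 440-fold lower number from compound 3 to compound 4 (2.64 log units; beyond the scatter) and a 170-fold lower number from compound 2 to compound 4 (2.22 log units; beyond the scatter), so the two earlier pyridyl groups do not speak for all pyridyl groups. It also outperforms the 3-fluorophenyl group, with a 5.0-fold lower number from compound 1 to compound 4 (0.70 log units; beyond the scatter), which makes compound 4 the strongest inhibitor of the four, its steps to all the others lying beyond the scatter. The methoxy group and the point of attachment on the pyridine ring change together in this step, and nothing measured here gives a reason for the large drop.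

On these data alone, it remains open how much of the gain belongs to the methoxy group and how much to the attachment point. A plain pyridin-4-yl group would help separate the two, and a dimethylamino group in place of the methoxy would show whether its oxygen is needed.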